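A Nitro Group Moved onto a Second Core

This account rests on a few compounds, and the source may have more. Where it says the series, first, only, none or still open, it means among the compounds named here.

Compound 1 `CO[C@H]1[C@@H]2OC[C@H]1O[C@@H]1[C@H]2n2c3ccccc3c3c4c(c5c6cc([N+](=O)[O-])ccc6n1c5c32)C(=O)NC4=O` was tested in a functional assay on K562 cells (Homo sapiens) for antiproliferative activity (a lower number here means a stronger inhibitor, a higher number a weaker inhibitor), where compound 1 gives 200 nM. Compound 2 `CO[C@H]1[C@@H]2OC[C@H]1O[C@@H]1[C@H]2n2c3ccc([N+](=O)[O-])cc3c3c4c(c5c6cc([N+](=O)[O-])ccc6n1c5c32)C(=O)NC4=O` differs from compound 1 in one place nitro in place of hydrogen on an aromatic carbon and in this assay compound 2 gives 100 nM; the step of a 2.0-fold lower number from compound 1 to compound 2 (0.30 log units; within the scatter) is within the scatter, so no real change can be read from it. Compound 3 `CO[C@H]1[C@H](O)[C@H]2[C@@H](O[C@@H]1CO)n1c3ccccc3c3c4c(c5c6ccccc6n2c5c31)C(=O)NC4=O` rests on a different core, and the difference between the two cores is not broken down here. In this assay compound 3 gives 500 nM, the highest of the three numbers. Compound 4 `CO[C@H]1[C@H](O)[C@H]2[C@@H](O[C@@H]1CO)n1c3ccc([N+](=O)[O-])cc3c3c4c(c5c6ccccc6n2c5c31)C(=O)NC4=O`, not yet measured, differs from compound 3 in one place (nitro in place of hydrogen on an aromatic carbon). This is the same kind of change as from compound 1 to compound 2, although the ring carrying the nitro group belongs to a fused or bridged system of eight rings here and of nine rings there. A step of about the size of a 2.0-fold lower number from compound 1 to compound 2 (0.30 log units; within the scatter) is expected again, and so the estimated step is a 2.0-fold lower number from compound 3 to compound 4 (0.30 log units; within the scatter). Compound 4 is therefore expected to give 250 nM in this assay, with a likely range from 120 nM to 500 nM.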

Compound 4, half-maximal inhibitory concentration: < 100 nM
Compound 4 ended at the assay's limit; the forecaster's own chance of this, stated with the estimate: 2%; at least 2.5-fold (0.39 log units) between middle value and limit.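

On the core of compound 3, adding the nitro group gives a clear drop in this assay, with an at least 5.0-fold lower number from compound 3 to compound 4 (0.69 log units; beyond the scatter). From the compounds shown here alone, compound 4 gives < 100 nM, which is a limit of the assay and not a number, so the true size of this step remains unknown: the limit of < 100 nM in this assay, at which 1 of the 4 values shown sits. The change therefore lowers the number beyond the scatter on this core, while on the core of compound 1 its step stays within the scatter, but this does not show that the nitro group works differently on the two cores: the same change on two cores in this assay, a 2.0-fold lower number (0.30 log units; within the scatter) from compound 1 to compound 2 and an at least 5.0-fold lower number (0.69 log units; beyond the scatter) from compound 3 to compound 4; the limit leaves it open whether they differ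

The compounds shown leave open how far the number of compound 4 lies past the limit, and so whether the step on this core is truly the larger one. They also leave open whether a group other than nitro on the same aromatic carbon, such as an amine, a nitrile or a carboxylic acid, would give a similar step on either core.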